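Benzothiazolyl benzohydrazones: aryl swap at the hydrazone carbon

A few compounds are considered here, and "the series" means these few. Any claim that something is new, unique, unknown or untested is made for them only; others in the source may bear on it.

Measured so far in an assay on isolated protein for inhibition of Maltase-glucoamylase (Homo sapiens), with a stated time of 15 min; on this read-out higher numbers stand for weaker inhibition and lower numbers for stronger inhibition:
- compound 1 `O=C(N/N=C\c1ccccn1)c1ccc(-c2nc3ccccc3s2)cc1`: 10200 nM
- compound 2 `O=C(N/N=C/c1cccs1)c1ccc(-c2nc3ccccc3s2)cc1`: 8480 nM

Compound 2 has the lowest of the two numbers, with compound 1 nearest at a 1.2-fold lower number from compound 1 to compound 2 (0.08 log units; within the scatter). Compound 3 `O=C(N/N=C/c1ccc(O)c(O)c1)c1ccc(-c2nc3ccccc3s2)cc1` differs from compound 2 by 3,4-dihydroxyphenyl in place of thiophen-2-yl on a carbon with a double bond to nitrogen. For the measured compounds named here, the only step that bears on this is the aryl exchange at the same position from compound 1 to compound 2, a 1.2-fold lower number from compound 1 to compound 2 (0.08 log units; within the scatter), which stayed within the scatter. Going by the values given here, no step involving hydroxyl groups has been measured, so the expectation leans on the near-flat aryl swap alone, widened for uncertainty. Compound 3 is therefore expected to give about 6500 nM, between 2200 nM and 16000 nM. This estimate implies a step of a 1.3-fold lower number from compound 2 to compound 3 (0.12 log units; within the scatter), expected to stay within the scatter.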

Compound 3, half-maximal inhibitory concentration: 15100 nM
Compound 3: middle estimate off by 2.3-fold (0.37 log units), on the low side; low and high end bracket the measured number.
By their numbers in this assay, from the lowest: compounds 2, 1 and 3 (each within the scatter of the next).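

Putting 3,4-dihydroxyphenyl in place of thiophen-2-yl on a carbon with a double bond to nitrogen gives a 1.8-fold higher number from compound 2 to compound 3 (0.25 log units; within the scatter) in this assay. This position therefore accepts a carbon-only aromatic ring bearing hydroxyl groups without the step leaving the scatter, as was also the case for the exchange of two hetero-aromatic rings, a 1.2-fold lower number from compound 1 to compound 2 (0.08 log units; within the scatter) here. Nothing measured on these compounds offers an explanation for the size of this step. From the compounds shown here alone, whether a single hydroxyl group behaves like the pair remains open. So does whether an amine, a carboxylic acid or a longer alkyl chain at this carbon would move the number beyond the scatter.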